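Shifting One Hydroxyl on a Three-Armed Core

The compounds below may be only part of what the source reports. "The series", "measured", "known", "first", "only" and "open" are said of these compounds alone.

Compound 1 `Oc1cccc(-c2cc(-c3cccc(O)c3)nc(-c3ccccc3O)c2)c1` was tested in an ADME assay on HEK293 cells (Homo sapiens) for cytotoxicity, read by CCK-8 assay, with a stated time of 4 days; on this read-out lower numbers stand for stronger inhibition and higher numbers for weaker inhibition. In this assay compound 1 gives only a limit, > 50000 nM. Compound 2 `Oc1ccc(-c2cc(-c3cccc(O)c3)cc(-c3ccc(O)cc3)n2)cc1` likewise gives only a limit in this assay, > 50000 nM. Compound 1 thus sits at the limit of > 50000 nM in this assay, at which 2 of the 2 values shown sit, and no number separates it from compound 2. Compound 3 `Oc1cccc(-c2cc(-c3cccc(O)c3)nc(-c3cccc(O)c3)c2)c1` is not yet measured; it differs from compound 1 by 3-hydroxyphenyl in place of 2-hydroxyphenyl on an aromatic carbon. Among the compounds with values here, no measured pair shows this change, and no step beyond the scatter is expected in this assay. Compound 3 is therefore estimated at 60000 nM, in the range 20000 nM to 200000 nM, most likely again only a limit. The step from compound 1 to compound 3 is expected to be a step that the limit leaves unreadable from compound 1 to compound 3.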

Compound 3, half-maximal inhibitory concentration: 740 nM
Beside the measured number, compound 3's estimate is 81-fold (1.91 log units) above it; measured number below the stated range.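

In this assay, 3-hydroxyphenyl in place of 2-hydroxyphenyl next to the ring nitrogen gives an at least 67-fold lower number from compound 1 to compound 3 (1.82 log units; beyond the scatter). At this one position, then, where the hydroxyl sits on the arm matters, even though the two compounds have the same atoms. The full size of the step cannot be read, since compound 1 gives only a limit: the limit of > 50000 nM in this assay, at which 2 of the 3 values shown sit.

This single pair sets no general rule for the other arms of the shared core. Also open, on these data alone, is what an amine or a carboxylic acid would do in place of the hydroxyl on this arm.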